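From vinyl to ethoxycarbonyl on an aromatic carbon

The compounds below may be only part of what the source reports. "The series", "measured", "known", "first", "only" and "open" are said of these compounds alone.

Going by the values given here, in a functional assay on MCF7 cells (Homo sapiens) for inhibition, read by CCK-8 assay, with a stated time of 48 h (a higher number here means a weaker inhibitor, a lower number a stronger inhibitor), compound 2 `C=Cc1ccc(-c2cc3nccc(-c4cc(OC)c(OC)c(OC)c4)n3n2)cc1` gives 193 nM, the lower of the two numbers so far, and compound 1 `COc1cc(-c2ccnc3cc(-c4ccc(C(F)(F)F)cc4)nn23)cc(OC)c1OC` gives 2440 nM. Compound 3 `CCOC(=O)c1ccc(-c2cc3nccc(-c4cc(OC)c(OC)c(OC)c4)n3n2)cc1` carries ethoxycarbonyl in place of vinyl on an aromatic carbon, para to a large group: ethoxycarbonyl in place of vinyl on an aromatic carbon. Among the compounds with values here, only one measured step changed this same place, the large 13-fold lower number from compound 1 to compound 2 (1.10 log units; beyond the scatter), so a swap here can shift the number considerably. With this single guide, a smaller move towards a higher number is expected, a 3.6-fold higher number from compound 2 to compound 3 (0.56 log units; beyond the scatter). For compound 3 the estimated value is 700 nM, with an expected range of 200 nM to 2500 nM.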

Compound 3, half-maximal inhibitory concentration: > 10000 nM
Compound 3: a limit, no number; the forecaster's own chance of this, stated with the estimate: 2%; middle value at least 14-fold (1.15 log units) from the limit.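

Compound 3 has no exact number, only a limit of the assay: the limit of > 10000 nM in this assay, at which 1 of the 3 values shown sits. At this place, para to a large group, ethoxycarbonyl in place of vinyl gives an at least 51-fold higher number from compound 2 to compound 3 (1.71 log units; beyond the scatter), and ethoxycarbonyl in place of trifluoromethyl gives an at least 4.0-fold higher number from compound 1 to compound 3 (0.61 log units; beyond the scatter). This position therefore tolerates less than the earlier step showed, since ethoxycarbonyl gives the weakest result of the three groups, and the limit leaves the full size of both steps unknown.

Still open, going by these compounds, is which part of ethoxycarbonyl matters. A carboxylic acid, an amide or a plain ethyl group at this place would help separate those parts.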